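A few compounds are considered here, and "the series" means these few. Any claim that something is new, unique, unknown or untested is made for them only; others in the source may bear on it.

Working notes, series measured in a functional assay on MCF7 cells (Homo sapiens) for cytotoxicity, read by sulforhodamine B assay, with a stated time of 48 h; on this read-out lower numbers stand for stronger inhibition and higher numbers for weaker inhibition:

- compound 1 `N#Cc1c(-c2ccc(Cl)cc2)cc(-c2ccc(Cl)cc2)n(C(=O)c2ccccc2)c1=O`: 2.6 ug/mL
- compound 2 `N#Cc1c(-c2ccc(Cl)cc2)cc(-c2ccc(Cl)cc2)n(CC(O)CCl)c1=O`: 4.6 ug/mL
- compound 3 `N#Cc1c(-c2ccc(Cl)cc2)cc(-c2ccc(Cl)cc2)n([C@@H]2O[C@H](COC(=O)c3ccccc3)[C@@H](OC(=O)c3ccccc3)[C@H]2OC(=O)c2ccccc2)c1=O`: 5.9 ug/mL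

Compound 2, at 4.6 ug/mL, lies within the scatter of both compound 1 and compound 3, so no order can be read among these pairs.

The next compound is compound 4 `C=CCn1c(-c2ccc(Cl)cc2)cc(-c2ccc(Cl)cc2)c(C#N)c1=O`, which is still unmeasured in this assay. Its difference from compound 2 is vinyl in place of 2-chloro-1-hydroxyethyl on a saturated chain carbon bound to an aromatic nitrogen. In words, this is vinyl in place of 2-chloro-1-hydroxyethyl on a saturated chain carbon bound to an aromatic nitrogen, or, cut one bond further out, 3-chloro-2-hydroxypropyl to allyl.

For the measured compounds named here, only one measured step bears on this change. Replacing the substituent on the aromatic nitrogen gave a 1.8-fold higher number from compound 1 to compound 2 (0.25 log units; within the scatter), which is within the scatter. Going by the values given here, this single step is thin evidence, and no measured step isolates the loss of the hydroxyl or the chlorine. No shift beyond the scatter is therefore expected in either direction.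

The expected size of a 1.0-fold lower number from compound 2 to compound 4 (0.01 log units; within the scatter) stays within the scatter. The estimate for compound 4 is 4.5 ug/mL, with an expected range of 2 ug/mL to 10 ug/mL.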

Compound 4, half-maximal inhibitory concentration: 19 ug/mL
Beside the measured number, compound 4's estimate is 4.2-fold (0.63 log units) below it; the measured number lies above the stated range.
By their numbers in this assay, from the lowest: compounds 1, 2 and 3 (each within the scatter of the next, the first and the last beyond it); then compound 4.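

In this assay the group on the aromatic nitrogen now produces steps beyond the scatter, which the earlier change at this place did not: a 4.1-fold higher number from compound 2 to compound 4 (0.62 log units; beyond the scatter) on going from 3-chloro-2-hydroxypropyl to allyl, and a 7.3-fold higher number from compound 1 to compound 4 (0.86 log units; beyond the scatter) on going from benzoyl to allyl. The read-out therefore responds to the choice of group at this place, and allyl is the less favourable group in both of these pairs. The first change removes the hydroxyl and the chlorine together, and no information here explains the step.

Which of the two atoms carries the difference stays open, since neither 2-hydroxypropyl nor 3-chloropropyl appears among the compounds shown. Also open, as far as these compounds go, is how an amine or a carboxylic acid on a longer chain would read at this place.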